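Replacing 4-acetylpiperazin-1-yl with morpholin-4-yl

This account rests on a few compounds, and the source may have more. Where it says the series, first, only, none or still open, it means among the compounds named here.

Of the compounds shown here, three sharing one core have been tested in a functional assay on MGC-803 cells (Homo sapiens) for inhibition, read by MTT assay, with a stated time of 48 h; on this read-out higher numbers stand for weaker inhibition and lower numbers for stronger inhibition. Compound 1 `COc1ccc(-c2coc3cc(OCCCSC(=S)N4CCN(Cc5ccccc5)CC4)ccc3c2=O)cc1` gives 43800 nM, compound 2 `COc1ccc(-c2coc3cc(OCCCSC(=S)N4CCN(C(C)=O)CC4)ccc3c2=O)cc1` gives 39400 nM, and compound 3 `COc1ccc(-c2coc3cc(OCCCSC(=S)N4CCN(C(=O)OC(C)(C)C)CC4)ccc3c2=O)cc1` gives 6070 nM. Compound 2 cannot be told apart from compound 1, and both numbers stand above that of compound 3.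

Compound 4 `COc1ccc(-c2coc3cc(OCCCSC(=S)N4CCOCC4)ccc3c2=O)cc1` has not yet been measured. It carries morpholin-4-yl in place of 4-acetylpiperazin-1-yl on a thiocarbonyl carbon.

The nearest evidence comes from changes on an amine nitrogen in a ring. Acetyl in place of benzyl gave a 1.1-fold lower number from compound 1 to compound 2 (0.05 log units; within the scatter). Tert-butoxycarbonyl in place of benzyl gave a 7.2-fold lower number from compound 1 to compound 3 (0.86 log units; beyond the scatter), and tert-butoxy in place of methyl on a carbonyl carbon gave a 6.5-fold lower number from compound 2 to compound 3 (0.81 log units; beyond the scatter). Among the compounds with values here, compound 4 has no tert-butoxycarbonyl group, and no measured step replaces the whole ring, so these steps are only a loose guide.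

No shift beyond the scatter is expected, and the expected change is a 1.3-fold lower number from compound 2 to compound 4 (0.12 log units; within the scatter). For compound 4 the estimated value is 30000 nM, with an expected range of 9000 nM to 80000 nM.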

Compound 4, half-maximal inhibitory concentration: 49600 nM
The estimate for compound 4 lay 1.7-fold (0.22 log units) below the measured number, within the range that was stated.
By their numbers in this assay, from the lowest: compound 3; then compounds 2, 1 and 4 (each within the scatter of the next).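

In this assay, within the data shown here, this is the first change of the whole ring group rather than of a substituent on its nitrogen, and it gives a 1.3-fold higher number from compound 2 to compound 4 (0.10 log units; within the scatter). At this place, on a thiocarbonyl carbon, morpholin-4-yl has neither the acetyl group nor the second ring nitrogen of 4-acetylpiperazin-1-yl, yet the number stays within the scatter of compound 2. Nothing measured here offers an explanation for this result.

The compounds shown leave open whether a piperidin-1-yl ring, with only its one nitrogen, or an open-chain dimethylamino group would also stay within the scatter. They also leave open whether a smaller carbamate, such as methoxycarbonyl on the piperazine nitrogen, would give the lower number seen with the tert-butoxycarbonyl group of compound 3.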